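The source may report more compounds than this note shows. Statements on the series, on what has been measured and on what is new or still open speak of the compounds shown alone.

Compound 1, `Clc1ccccc1CSc1nnc(-c2cnccn2)o1`, gives 15100 nM in a functional assay on SW 1116 cells (Homo sapiens) for antiproliferative activity, read by MTT assay, with a stated time of 48 h; on this read-out lower numbers stand for stronger inhibition and higher numbers for weaker inhibition.
Compound 2, `Brc1ccccc1CSc1nnc(-c2cnccn2)o1`, gives 2460 nM in this assay.
Compound 3, `Clc1cccc(CSc2nnc(-c3cnccn3)n2-c2ccccc2)c1`, gives 6610 nM in this assay.

Compound 1 and compound 2 share one core and differ in a single place: bromo in place of chloro on an aromatic carbon. That change gave a 6.1-fold lower number from compound 1 to compound 2 (0.79 log units; beyond the scatter). Compound 3 rests on a different core, and the difference between the two cores is not broken down here. Compound 4, `Brc1cccc(CSc2nnc(-c3cnccn3)n2-c2ccccc2)c1`, has not yet been measured; it differs from compound 3 by bromo in place of chloro on an aromatic carbon. Among the compounds with values here, this is the same kind of change as the one between compound 1 and compound 2, but not the same: in compound 1 the chloro sits ortho to a large group, while in compound 3 it sits meta to a large group, and the surrounding core differs as well. Within the data shown here, for compound 4 a smaller step than the earlier one is expected, a 2.4-fold lower number from compound 3 to compound 4 (0.37 log units; beyond the scatter), because a 6.1-fold lower number from compound 1 to compound 2 (0.79 log units; beyond the scatter) was seen on another core and at another place, and only this one example is available. Compound 4 is therefore estimated at 2800 nM, with a likely range from 900 nM to 7500 nM.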

Compound 4, half-maximal inhibitory concentration: 5030 nM
Compound 4: the middle estimate sits 1.8-fold (0.25 log units) below what was measured, and the stated range covers the measured number.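

In this assay, bromo in place of chloro on the aromatic carbon of the 3-chlorobenzyl group gave a 1.3-fold lower number from compound 3 to compound 4 (0.12 log units; within the scatter), so on this core the swap cannot be told apart from the ordinary spread of repeated measurements. The large step seen on the other core therefore did not carry over, and the two results really do differ: the same change on two cores in this assay, a 6.1-fold lower number (0.79 log units; beyond the scatter) from compound 1 to compound 2 and a 1.3-fold lower number (0.12 log units; within the scatter) from compound 3 to compound 4, 4.7-fold (0.67 log units) apart, beyond the scatter of two such steps
Within the data shown here, what this does not show is the reason, since the two pairs differ both in their core and in where the chloro sits on the ring, and with only one pair of each kind, these two differences cannot be separated.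

The compounds shown leave open whether another group at this place on the core of compound 3, such as a methyl, a methoxy or an amine, would shift the number beyond the scatter. They also leave open whether the core of compound 1, carrying its halogen at the place it has in compound 3, would respond to this swap as strongly as before.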